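The compounds below may be only part of what the source reports. "The series", "measured", "known", "first", "only" and "open" are said of these compounds alone.

Measured so far in an ADME assay on a cell-free system (plasma, Rattus norvegicus) for protein binding; on this read-out lower numbers stand for a smaller free fraction and higher numbers for a larger free fraction:
compound 1 `N#Cc1ccc(O[C@H]2CN(S(=O)(=O)c3ccc(Cl)cc3Cl)C[C@@]2(O)CN)cc1F` gives 0.036
compound 2 `N#Cc1ccc(O[C@H]2CN(S(=O)(=O)c3ccc(Cl)cn3)C[C@@]2(O)CO)cc1F` gives 0.18
compound 3 `N#Cc1ccc(O[C@H]2CN(S(=O)(=O)c3ccc(Cl)cc3)C[C@@]2(O)CO)cc1F` gives 0.035

Compound 2 stands highest of the three numbers; the nearest is compound 1, the furthest compound 3, both beyond the scatter. Within the data shown here, the one single-place step, a 5.1-fold lower number from compound 2 to compound 3 (0.71 log units; beyond the scatter), concerns the group on the sulfonyl sulfur and so does not touch the change at hand. Compound 4 `N#Cc1ccc(O[C@H]2CN(S(=O)(=O)c3ccc(Cl)cn3)C[C@@]2(O)CN)cc1F` differs from compound 2 by amino in place of hydroxy on a saturated chain carbon bound to a saturated ring carbon. Among the measured compounds shown here, no single-place step tests this change. Compound 1 carries aminomethyl and compound 3 hydroxymethyl, but they also differ on the sulfonyl sulfur; their two values lie within the scatter of each other. From compound 2 to compound 4 no step beyond the scatter is therefore expected, no change at the digits printed from compound 2 to compound 4 (within the scatter). Compound 4 is estimated at 0.18, in the range 0.08 to 0.36.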

Compound 4, unbound fraction: 0.14
Compound 4: the middle estimate sits 1.3-fold (0.11 log units) above what was measured; the measured number falls inside the stated range.
By their numbers in this assay, from the lowest: compounds 3 and 1 (each within the scatter of the next); then compounds 4 and 2 (each within the scatter of the next).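

In this assay, the first direct test of this change on the saturated chain carbon gives a step within the scatter (a 1.3-fold lower number from compound 2 to compound 4 (0.11 log units; within the scatter)), so hydroxymethyl and aminomethyl cannot be told apart while 5-chloropyridin-2-yl sits on the sulfonyl sulfur. With aminomethyl kept in place, changing the group on the sulfur does show (a 3.9-fold higher number from compound 1 to compound 4 (0.59 log units; beyond the scatter)). No measured evidence here explains either result.

On these data alone, whether the change reads the same with a 4-chlorophenyl group on the sulfur stays open. So does whether a dimethylamino group or a carboxylic acid at this place would behave like amino.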